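Replacing the amide chain with a thioether chain

The compounds below may be only part of what the source reports. "The series", "measured", "known", "first", "only" and "open" are said of these compounds alone.

Measured compounds:
compound 1 `C#CCn1c(=N)sc2cc(OC(F)(F)F)ccc21` — 4 mg/kg
compound 2 `N=c1sc2cc(OC(F)(F)F)ccc2n1CC(=O)O` — > 10 mg/kg
compound 3 `CCN(CC)C(=O)Cn1c(=N)sc2cc(OC(F)(F)F)ccc21` — 9 mg/kg

In a functional assay on the whole organism with Rattus norvegicus as the target (a higher number here means that more compound is needed for the effect, a lower number that less compound is needed), compound 1 gives 4 mg/kg. For compound 2 the assay reports only a limit, > 10 mg/kg. Compound 3 gives 9 mg/kg, the higher of the two actual numbers, with compound 1 as its nearest neighbour at a 2.3-fold higher number from compound 1 to compound 3 (0.35 log units; beyond the scatter). The other steps shown are an at least 2.5-fold higher number from compound 1 to compound 2 (0.39 log units; beyond the scatter) and an at least 1.1-fold lower number from compound 2 to compound 3 (0.04 log units; that floor lies within the scatter); the latter rests on a limit (the limit of > 10 mg/kg in this assay, at which 1 of the 3 values shown sits).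

Compound 4 `CCCSCCn1c(=N)sc2cc(OC(F)(F)F)ccc21` differs from compound 3 in one place: (propylsulfanyl)methyl in place of diethylcarbamoyl on a saturated chain carbon bound to an aromatic nitrogen. Among the measured compounds shown here, no measured step exchanges an amide for a thioether chain, so the closest guide is compound 1, whose plain ethynyl chain on the same carbon gave the lower number 4 mg/kg, and the step of a 2.3-fold higher number from compound 1 to compound 3 (0.35 log units; beyond the scatter) that the diethylcarbamoyl brought. Removing that carbonyl is therefore expected to move the number back toward compound 1, a modest step downward as a 1.8-fold lower number from compound 3 to compound 4 (0.26 log units; within the scatter). Compound 4 is expected to give about 5 mg/kg, within 2 mg/kg to 12 mg/kg.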

Compound 4, dose for half-maximal effect: 2.4 mg/kg
For compound 4 the middle estimate is 2.1-fold (0.32 log units) above the measured one; the range from low to high includes it.
By their numbers in this assay, from the lowest: compounds 4 and 1 (each within the scatter of the next); then compound 3. At a limit, above all of these: compound 2.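

In this assay, the exchange of the amide chain for the thioether chain gives a 3.8-fold lower number from compound 3 to compound 4 (0.57 log units; beyond the scatter), so at this saturated chain carbon the diethylcarbamoyl can be replaced by a chain without a carbonyl, and the number falls beyond the scatter. The earlier compounds shown here showed only higher numbers when ethynyl was replaced, whereas the (propylsulfanyl)methyl gives a 1.7-fold lower number from compound 1 to compound 4 (0.22 log units; within the scatter), which leaves compound 1 and compound 4 unseparated. The step of an at least 4.1-fold lower number from compound 2 to compound 4 (0.61 log units; beyond the scatter) gives only a floor, and compound 2 carries a limit rather than a number: the limit of > 10 mg/kg in this assay, at which 1 of the 4 values shown sits.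

The compounds shown leave open whether the sulfur itself matters, as a plain alkyl chain or an ether chain would tell, and whether a shorter or longer thioether chain would behave alike. They also leave open how a sulfone or an amine on this chain would compare.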